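The source may hold more compounds than are shown below. What is called first, only, known or untested is meant among the compounds shown, and "the series" means these compounds.

Measured compounds and values:
compound 1, `O=C(OCc1ccccc1)N1CCN(C(=S)SCc2cn(Cc3ccc(Cl)cc3)nn2)CC1`, gives > 128000 nM in a functional assay on ECa-109 cells (Homo sapiens) for inhibition, read by MTT assay, with a stated time of 72 h (on this read-out lower numbers stand for stronger inhibition and higher numbers for weaker inhibition), which is a limit of the assay and not a number.
compound 2, `CC(C)(C)OC(=O)N1CCN(C(=S)SCc2cn(Cc3cc(=O)oc4cc(O)ccc34)nn2)CC1`, gives > 128000 nM in this assay, again a limit rather than a number.

Compound 1 therefore stands where every value shown stands: at the limit of > 128000 nM in this assay, at which 2 of the 2 values shown sit. Within the data shown here, no pair of measured compounds differing in one place is available, so no measured step is known here.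

Compound 3, `Cc1ccc(Cn2cc(CSC(=S)N3CCN(C(=O)OCc4ccccc4)CC3)nn2)cc1`, differs from compound 1 by methyl in place of chloro on an aromatic carbon. Among the measured compounds shown here, since compound 1 reaches only the limit, and since the only other value also sits at that limit, no step beyond the usual scatter is expected in either direction. Compound 3 is expected to give about 200000 nM, with a range from 60000 nM to 700000 nM. The expected step that the limit leaves unreadable from compound 1 to compound 3 is estimated to be essentially none, with a high chance that this assay again reports only a limit for compound 3.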

Compound 3, half-maximal inhibitory concentration: 32600 nM
Compound 3: middle estimate off by 6.1-fold (0.79 log units), on the high side, and the stated range ends above it.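

In this assay, methyl in place of chloro on the aromatic ring gives an at least 3.9-fold lower number from compound 1 to compound 3 (0.59 log units; beyond the scatter), which means stronger inhibition. This place on the ring therefore matters: exchanging one heavy atom for another, with no ring, hydrogen-bond donor or acceptor, or charge entering or leaving, is enough to bring a compound off the limit that the other compounds shown sit at: the limit of > 128000 nM in this assay, at which 2 of the 3 values shown sit.

As far as these compounds go, for compound 1, the value > 128000 nM is a limit and not a number, so the step has only a lower bound and its true size stays unknown. The compounds shown compare only chloro and methyl at this place, so it remains open how an amine, a methoxy group or a longer chain such as propyl would fare. From the compounds shown here alone, whether the same exchange would have a similar effect on a different core also remains open.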